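Swapping an Amide Substituent Where Nothing Yet Inhibits

The source may hold more compounds than are shown below. What is called first, only, known or untested is meant among the compounds shown, and "the series" means these compounds.

Of the compounds shown here, three built on the same core have been tested. Compound 1 `CC1CCN(C(=O)CN(C)C(=O)c2ccc(S(C)(=O)=O)c([N+](=O)[O-])c2)CC1` carries a methyl-substituted piperidine on the far end of its chain. In an assay on isolated protein for inhibition of thyroid hormone receptor alpha (Homo sapiens), read by fluorescence polarization (on this read-out higher numbers stand for weaker inhibition and lower numbers for stronger inhibition), compound 1 reaches only a limit, > 60000 nM, not a number. Compound 2 `CC(C)N(C(=O)CCNC(=O)c1ccc(S(C)(=O)=O)c([N+](=O)[O-])c1)C(C)C` ends in a diisopropylamino group, and in this assay compound 2 likewise stops at a limit of > 60000 nM. Compound 3 `CS(=O)(=O)c1ccc(C(=O)NCCCC(=O)N2CCCCC2)cc1[N+](=O)[O-]` also gives only a limit, > 60000 nM. Compound 2 therefore stands exactly where the other two stand, at the limit, with no number of its own.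

The step that the two limits leave unreadable from compound 2 to compound 3 cannot be read, which follows from the limit of > 60000 nM in this assay, at which 3 of the 3 values shown sit.

Compound 4 `CS(=O)(=O)c1ccc(C(=O)NCCC(=O)N2CCc3ccccc32)cc1[N+](=O)[O-]` differs from compound 2 by 2,3-dihydro-1H-indol-1-yl in place of diisopropylamino on a carbonyl carbon. Among the compounds with values here, the one measured step that touches this position gives no readable size, so no direction beyond the scatter can be expected. Compound 4 is expected to give about 60000 nM, within a range from 20000 nM to 150000 nM, most probably as another limit. The expected step of a number no higher from compound 2 to compound 4 (the limit leaves the size open) is thus essentially none.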

Compound 4, half-maximal inhibitory concentration: > 60000 nM
Compound 4 ended at the assay's limit; the forecaster's own chance of this, stated with the estimate: 75%; the middle value lies on the limit itself.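

Compound 2 and compound 4 both stop at a limit rather than a number, so no step can be read between them, which follows from this: the limit of > 60000 nM in this assay, at which 4 of the 4 values shown sit. The compounds shown leave open whether any change to the shared core gives a measurable value in this assay.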